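A few compounds are considered here, and "the series" means these few. Any claim that something is new, unique, unknown or untested is made for them only; others in the source may bear on it.

Compound 1 `CC(C)COC(=O)N1CCN(C(=O)c2nc(Nc3cc(C4CC4)[nH]n3)c3cc(Cl)ccc3n2)C[C@H]1C`: 46.9%
Compound 2 `C[C@@H]1CN(C(=O)c2nc(Nc3cc(C4CC4)[nH]n3)c3cc(Cl)ccc3n2)CCN1C(=O)OCc1ccccc1`: 96%

In an assay for inhibition of serine/threonine-protein kinase PAK 4 (Homo sapiens), read by FRET and Z'-LYTE, with a stated time of 60 min, tested at 50 uM, in the presence of a further agent that is not named here (a higher number here means a stronger effect of the compound at the concentration tested, a lower number a weaker effect), compound 1 gives 46.9% and stands lowest of the two numbers; its nearest neighbour is compound 2 with 96%. For the measured compounds named here, the only measured step at this position of the shared core is a number 49.1 percentage points higher from compound 1 to compound 2 (beyond the scatter), which is large and lies beyond the scatter. Compound 3 `C[C@@H]1CN(C(=O)c2nc(Nc3cc(C4CC4)[nH]n3)c3cc(Cl)ccc3n2)CCN1C(=O)OCOC(=O)C(C)(C)C` is not yet measured; it differs from compound 1 by ((tert-butyl)carbonyl)oxy in place of isopropyl on a saturated chain carbon bound to an oxygen next to a carbonyl group. This is a change at the same place as the measured step, but the entering group has no ring and brings two hydrogen-bond acceptors, so the measured step is only a loose guide. An increase in this assay is expected, estimated as a number 23.1 percentage points higher from compound 1 to compound 3 (beyond the scatter), with wide uncertainty. Compound 3 is therefore expected to give about 70% in this assay, within a range from 40% to 95%.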

Compound 3, a percentage reported as inhibition, at one concentration (the size of the read-out at that concentration, not a potency) in the serine/threonine-protein kinase PAK 4 assay: 60.5%
Estimate against measurement, compound 3: 9.5 percentage points above; low and high end bracket the measured number.
By their numbers in the serine/threonine-protein kinase PAK 4 assay, from the lowest: compound 1; then compound 3; then compound 2.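

In the serine/threonine-protein kinase PAK 4 assay compound 3 gives 60.5%, so a group with no ring also raises the number at this place, on a saturated chain carbon bound to an oxygen next to a carbonyl group: ((tert-butyl)carbonyl)oxy in place of isopropyl gives a number 13.6 percentage points higher from compound 1 to compound 3 (beyond the scatter). Phenyl remains clearly ahead of ((tert-butyl)carbonyl)oxy, with a number 35.5 percentage points lower from compound 2 to compound 3 (beyond the scatter), so the size of the gain depends strongly on which group enters here. In a physicochemical assay, read by HPLC, in phosphate buffer, with a stated time of 2 h, at pH 7.4 (on this read-out lower numbers stand for a less stable compound and higher numbers for a more stable compound), compound 1 gives 99% and compound 3 gives 97.7%. In the physicochemical assay, the change from isopropyl to ((tert-butyl)carbonyl)oxy gives a number 1.3 percentage points lower from compound 1 to compound 3 (within the scatter), so it leaves that read-out unchanged.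

Nothing given here accounts for these differences. On these data alone, whether an amine or a carboxylic acid at this place would approach the number of compound 2 or stay nearer that of compound 1 remains open.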